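Chloro in Place of Fluoro on the Phenylurea of Compound 3

The compounds below may be only part of what the source reports. "The series", "measured", "known", "first", "only" and "open" are said of these compounds alone.

Compound 3 `COc1cc(NC(C)CCCNC(=O)Nc2cccc(F)c2)c2ncccc2c1` stands highest of the three numbers in a functional assay on MCF7 cells (Homo sapiens) for inhibition, read by MTT assay, with a stated time of 72 h; a higher number here means a weaker inhibitor, a lower number a stronger inhibitor: compound 3 gives 18000 nM. Its nearest neighbour is compound 2 `COc1cc(NC(C)CCCNC(=O)NNC(=O)Nc2ccc(O)cc2)c2ncccc2c1`, which in this assay gives 2600 nM, and furthest away lies compound 1 `COc1cc(NC(C)CCCNC(=O)NNC(=O)Nc2ccc(Br)cc2)c2ncccc2c1`, which gives 100 nM. The steps that lead to compound 3 are a 6.9-fold higher number from compound 2 to compound 3 (0.84 log units; beyond the scatter) and a 180-fold higher number from compound 1 to compound 3 (2.26 log units; beyond the scatter); both replace the whole group on the amide-type nitrogen and say nothing about the halogen itself. For the measured compounds named here, the only halogen exchange measured, a 26-fold higher number from compound 1 to compound 2 (1.41 log units; beyond the scatter), swaps bromo for hydroxy, a change in hydrogen-bond donors that is absent here. Compound 4 `COc1cc(NC(C)CCCNC(=O)Nc2cccc(Cl)c2)c2ncccc2c1` differs from compound 3 in one place: chloro in place of fluoro on an aromatic carbon. Going by the values given here, no measured pair bears directly on such a swap, so compound 4 is expected to give a number close to that of compound 3, with a step of a 1.5-fold lower number from compound 3 to compound 4 (0.18 log units; within the scatter) judged not to exceed the scatter. Compound 4 is thus estimated at 12000 nM, within the range 4000 nM to 40000 nM.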

Compound 4, half-maximal inhibitory concentration: 11000 nM
Estimate against measurement, compound 4: 1.1-fold (0.04 log units) above; the range from low to high includes it.
By their numbers in this assay, from the lowest: compound 1; then compound 2; then compounds 4 and 3 (each within the scatter of the next).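

For the compounds shown here, this is the first direct reading of a halogen exchange at this place: in this assay, chloro in place of fluoro on an aromatic carbon of the six-membered ring gives a 1.6-fold lower number from compound 3 to compound 4 (0.21 log units; within the scatter), so compounds 3 and 4 cannot be told apart. The larger differences remain tied to the group on the amide-type nitrogen, with 3-chlorophenyl giving a 4.2-fold higher number from compound 2 to compound 4 (0.63 log units; beyond the scatter) and a 110-fold higher number from compound 1 to compound 4 (2.04 log units; beyond the scatter), so the new halogen does not narrow the gap to compound 1 beyond the scatter. Nothing available gives a cause for these numbers.

On these data alone, what a trifluoromethyl, an amine or a carboxylic acid would do on this same aromatic carbon remains open. Also open, as far as these compounds go, is whether chloro in place of bromo on compound 1 would give a similarly small step.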